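The source may report more compounds than this note shows. Statements on the series, on what has been measured and on what is new or still open speak of the compounds shown alone.

Compound 1 `Cc1cc(S(N)(=O)=O)ccc1NC(=O)COc1ccc(Cl)cc1NC(=O)c1ccccc1` is the starting point. Going by the values given here, in a functional assay on C8166 cells (Homo sapiens) for cytotoxicity, read by MTT assay (a lower number here means that less compound is tolerated, a higher number that more compound is tolerated), compound 1 gives 207000 nM, the highest of the three numbers measured so far. Compound 2 `Cc1cc(S(N)(=O)=O)ccc1NC(=O)COc1ccc(Cl)cc1NC(=O)c1cccc([N+](=O)[O-])c1` gives 58800 nM in this assay, and compound 3 `Cc1cc(S(N)(=O)=O)ccc1NC(=O)COc1ccc(Cl)cc1NC(=O)c1ccc(Cl)cc1Cl` gives 61100 nM. Compound 4 `Cc1cc(S(N)(=O)=O)ccc1NC(=O)COc1ccc(Cl)cc1NC(=O)c1cc(Cl)cc(Cl)c1` differs from compound 1 by 3,5-dichlorophenyl in place of phenyl on a carbonyl carbon. Among the compounds with values here, two measured steps bear on this change, both altering the same phenyl on the carbonyl carbon: a 3.5-fold lower number from compound 1 to compound 2 (0.55 log units; beyond the scatter) and a 3.4-fold lower number from compound 1 to compound 3 (0.53 log units; beyond the scatter). Both steps moved the number downward by a similar amount, so a step of comparable size and direction is expected here, a 3.2-fold lower number from compound 1 to compound 4 (0.50 log units; beyond the scatter). Compound 4 is therefore estimated to give 65000 nM in this assay, with a likely range from 25000 nM to 170000 nM.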

Compound 4, half-maximal cytotoxic concentration: 72400 nM
Estimate against measurement, compound 4: 1.1-fold (0.05 log units) below, within the range that was stated.
By their numbers in this assay, from the lowest: compounds 2, 3 and 4 (each within the scatter of the next); then compound 1.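

In this assay the 3,5-dichlorophenyl group on the carbonyl carbon also lowers the number, giving a 2.9-fold lower number from compound 1 to compound 4 (0.46 log units; beyond the scatter), so all three substituted phenyl groups shown differ from plain phenyl in the same direction. Placing it in the position of 2,4-dichlorophenyl gives a 1.2-fold higher number from compound 3 to compound 4 (0.07 log units; within the scatter), and placing it in the position of 3-nitrophenyl gives a 1.2-fold higher number from compound 2 to compound 4 (0.09 log units; within the scatter), so these three groups cannot be told apart here. Nothing available explains the drop from plain phenyl.

On these data alone, whether a single chlorine would give a similar number remains open. So does the outcome with an amine or a carboxylic acid on this phenyl.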